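The compounds below may be only part of what the source reports. "The series", "measured", "known", "first", "only" and "open" are said of these compounds alone.

Compound 1 `O=C1N/C(=N/c2csc(-c3ccc(Cl)cc3)c2)S/C1=C\c1ccc2ccccc2c1`, compound 2 `O=C1N/C(=N/c2csc(-c3ccc(Cl)cc3)c2)S/C1=C\c1ccc(F)cc1`, compound 3 `O=C1N/C(=N/c2nc(-c3ccc(Cl)cc3)cs2)S/C1=C\c1ccc2ccccc2c1`.

In a functional assay on SW-620 cells (Homo sapiens) for cytotoxicity, read by MTT assay, with a stated time of 72 h (on this read-out lower numbers stand for stronger inhibition and higher numbers for weaker inhibition), compound 1 gives > 50000 nM, a limit of the assay rather than a number. In this assay compound 2 gives 8700 nM. In this assay compound 3 gives 20300 nM, the highest number among the measured ones. The change 4-fluorophenyl in place of naphthalen-2-yl on a double-bonded chain carbon bound to a double-bonded ring carbon produces an at least 5.7-fold lower number from compound 1 to compound 2 (0.75 log units; beyond the scatter); its true size is only bounded, since it starts from the limit of > 50000 nM in this assay, at which 1 of the 3 values shown sits. Compound 4 `O=C1N/C(=N/c2nc(-c3ccc(Cl)cc3)cs2)S/C1=C\c1ccc(F)cc1` has not yet been measured. It differs from compound 3 by 4-fluorophenyl in place of naphthalen-2-yl on a double-bonded chain carbon bound to a double-bonded ring carbon, the same change as that made from compound 1 to compound 2. The difference between the two cores is not broken down here. Compound 4 is expected to give a 4.1-fold lower number from compound 3 to compound 4 (0.61 log units; beyond the scatter) in this assay, an expectation that rests on the step seen an at least 5.7-fold lower number from compound 1 to compound 2 (0.75 log units; beyond the scatter). Compound 4 is thus estimated at 5000 nM, expected between 1500 nM and 15000 nM.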

Compound 4, half-maximal inhibitory concentration: > 50000 nM
Compound 4: a limit, no number; the forecaster's own chance of this, stated with the estimate: 5%; at least 10-fold (1.00 log units) between middle value and limit.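

In this assay compound 4 gives > 50000 nM, a limit of the assay and not a number. The same replacement gives an at least 2.4-fold higher number from compound 3 to compound 4 (0.39 log units; beyond the scatter), so the drop seen on the core of compound 1 did not carry over to the core of compound 3: the same change on two cores in this assay, an at least 5.7-fold lower number (0.75 log units; beyond the scatter) from compound 1 to compound 2 and an at least 2.4-fold higher number (0.39 log units; beyond the scatter) from compound 3 to compound 4, at least 14-fold (1.15 log units) apart, beyond the scatter of two such steps This shows that the change cannot be transferred from one of these cores to the other, but neither step has an exact size, and a single pair on each core gives no general rule for the series: the limit of > 50000 nM in this assay, at which 2 of the 4 values shown sit.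

As far as these compounds go, it remains open whether a smaller replacement, such as an unsubstituted phenyl, or a 4-methoxyphenyl at the same place, would also behave differently on the two cores.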